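This account rests on a few compounds, and the source may have more. Where it says the series, first, only, none or still open, it means among the compounds named here.

The account follows one change made to compound 2 `O=S(=O)(Nc1ccc2oc(-c3ccccc3)nc2c1)c1ccccc1Cl`, which in an ADME assay on HEK293 cells (Homo sapiens) for cytotoxicity, read by resazurin assay, with a stated time of 48 h (on this read-out higher numbers stand for lower toxicity in this test and lower numbers for higher toxicity in this test), gives 73000 nM. Its closest relative is compound 1 `O=S(=O)(Nc1ccc2oc(-c3ccccc3)nc2c1)c1ccccc1C(F)(F)F`, which in this assay gives 80000 nM. Among the measured compounds shown here, the step of a 1.1-fold lower number from compound 1 to compound 2 (0.04 log units; within the scatter) is the only measured step in the set. Compound 3 `CS(=O)(=O)Nc1ccc(-c2nc3ccccc3o2)cc1` is reported only as a limit of the assay, and in this assay compound 3 gives > 100000 nM. Among the two plain numbers, compound 2 stands lowest, with compound 1 sitting close to it; one further value is a limit (the limit of > 100000 nM in this assay, at which 1 of the 3 values shown sits).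

The unmeasured compound 4 `O=S(=O)(Nc1ccc2oc(-c3ccccc3)nc2c1)c1ccc(Cl)s1` differs from compound 2 in a single place: 5-chlorothiophen-2-yl in place of 2-chlorophenyl on a sulfonyl sulfur. For the measured compounds named here, the one measured step, from compound 1 to compound 2, altered the same ring on the sulfonyl sulfur and stayed within the scatter, so it offers little reason to expect a larger shift now. The step from compound 2 to compound 4 is therefore expected to be a 1.0-fold higher number from compound 2 to compound 4 (0.01 log units; within the scatter), with no direction favoured beyond the scatter. On that basis compound 4 is estimated to give 75000 nM in this assay, within the range 35000 nM to 150000 nM.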

Compound 4, half-maximal cytotoxic concentration: > 100000 nM
Compound 4 ended at the assay's limit; the forecaster's own chance of this, stated with the estimate: 25%; at least 1.3-fold (0.12 log units) between middle value and limit.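

From the compounds shown here alone, the change of 2-chlorophenyl to 5-chlorothiophen-2-yl on a sulfonyl sulfur gives an at least 1.3-fold higher number from compound 2 to compound 4 (0.13 log units; that floor lies within the scatter), and this is only a floor, so the true size of the step remains unknown. In this assay compound 4 gives > 100000 nM, which is a limit of the assay and not a number. Unlike the earlier step at this place, which could be read in full, this one shows only that a five-membered aromatic ring with 1 hetero atom can stand on the sulfonyl sulfur with the read-out reaching the top of its range, where compound 4 now sits: the limit of > 100000 nM in this assay, at which 2 of the 4 values shown sit.

Since compound 4 has no number of its own, the compounds shown leave open how far it lies beyond that limit and therefore whether the step from compound 2 truly exceeds the usual scatter. They also leave open whether a carboxylic acid, an amine or a longer chain carried on the ring at this place would keep the read-out at that limit in this assay or bring it back into the measurable range.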